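Nitro for fluoro on the benzyl arm of compound 1

The source may report more compounds than this note shows. Statements on the series, on what has been measured and on what is new or still open speak of the compounds shown alone.

Compound 1 `Cc1cc(N2CC[C@@H](C)[C@@H](N(C)c3ncnc4[nH]ccc34)C2)n2nc(SCc3ccc(F)cc3)nc2n1`: in a functional assay on MGC-803 cells (Homo sapiens) for inhibition, read by MTT assay, with a stated time of 72 h (on this read-out higher numbers stand for weaker inhibition and lower numbers for stronger inhibition), compound 1 gives 11900 nM.
Compound 2 `CCCCCc1c(C)nc2nc(SCc3ccc(Cl)cc3)nn2c1N1CC[C@@H](C)[C@@H](N(C)c2ncnc3[nH]ccc23)C1`: in this assay compound 2 reaches only a limit, > 100000 nM.
Compound 3 `CCc1cc(N2CC[C@@H](C)[C@@H](N(C)c3ncnc4[nH]ccc34)C2)n2ncnc2n1`: in this assay compound 3 gives 80200 nM.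

Among the two numbers, compound 1 holds the lowest; compound 3 is its nearest neighbour, with a higher number that lies beyond the scatter. Compound 2 sits at the limit of > 100000 nM in this assay, at which 1 of the 3 values shown sits, so nothing more than that limit is known of it.

Compound 4 `Cc1cc(N2CC[C@@H](C)[C@@H](N(C)c3ncnc4[nH]ccc34)C2)n2nc(SCc3ccc([N+](=O)[O-])cc3)nc2n1` follows from compound 1 by a single change, (nitro in place of fluoro on an aromatic carbon). Within the data shown here, no measured pair isolates this exchange, so the step has to be judged without a direct precedent. The change keeps the benzyl arm that compound 3 lacks, and the step is expected to be modest, if anything toward a slightly higher number.

The step of a 1.3-fold higher number from compound 1 to compound 4 (0.13 log units; within the scatter) is the expected outcome in this assay. Compound 4 is expected to give 16000 nM in this assay. The expected range for compound 4 runs from 4000 nM to 60000 nM.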

Compound 4, half-maximal inhibitory concentration: 27000 nM
Compound 4: middle estimate off by 1.7-fold (0.23 log units), on the low side; the measured number falls inside the stated range.
By their numbers in this assay, from the lowest: compound 1; then compound 4; then compound 3. At a limit, above all of these: compound 2.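

In this assay, among these compounds, the exchange of 4-fluorobenzyl for 4-nitrobenzyl isolates a single change on the benzyl arm for the first time, and it gives a 2.3-fold higher number from compound 1 to compound 4 (0.36 log units; beyond the scatter), a modest step beyond the scatter. The carbon para to a large group is therefore not indifferent to what it carries, yet replacing one fluorine atom with the three heavy atoms of a nitro group costs only this much. Nothing shown bears on the cause of this step.

Going by these compounds, whether an amine or a carboxylic acid on the same carbon would give a number nearer to that of compound 1 or to that of compound 4 remains open. Also open, on these data alone, is whether a longer chain between the sulfur and the phenyl ring would change the number at all.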